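The compounds below may be only part of what the source reports. "The series", "measured", "known", "first", "only" and "open" are said of these compounds alone.

Measured so far in a functional assay on NFF cells (Homo sapiens) for antiproliferative activity; on this read-out lower numbers stand for stronger inhibition and higher numbers for weaker inhibition:

compound 1, `O=C(CCCCC[C@H](NC(=O)c1cc2ccccc2[nH]1)C(=O)NCc1ccccc1)NO`, with 1260 nM;
compound 2, `O=C(CCCCC[C@H](NC(=O)OCc1ccccc1)C(=O)NCc1ccccc1)NO`, with 1520 nM.

For the measured compounds named here, compound 2 shows the larger of the two numbers in this assay, but its only neighbour is compound 1 and the step of a 1.2-fold higher number from compound 1 to compound 2 (0.08 log units; within the scatter) lies within the scatter, so the two cannot be told apart. Compound 3, `O=C(CCCCC[C@H](NC(=O)c1cc2c(O)cccc2[nH]1)C(=O)NCc1ccccc1)NO`, has not yet been measured in this assay. It differs from compound 2 in one place: 4-hydroxy-1H-indol-2-yl in place of benzyloxy on a carbonyl carbon. Going by the values given here, only one measured step bears on this change, the exchange of 1H-indol-2-yl for benzyloxy on the same carbonyl carbon, and it was a 1.2-fold higher number from compound 1 to compound 2 (0.08 log units; within the scatter). Returning to an indol-2-yl type group on that carbonyl carbon therefore carries no expectation of a shift beyond the scatter, and the added hydroxy group on the indole has no measured precedent here. The expected step of a 1.4-fold lower number from compound 2 to compound 3 (0.14 log units; within the scatter) is accordingly small. Compound 3 is estimated at 1100 nM in this assay, with a range from 400 nM to 3200 nM.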

Compound 3, half-maximal inhibitory concentration: 2210 nM
The estimate for compound 3 lay 2.0-fold (0.30 log units) below the measured number, and the stated range covers the measured number.
By their numbers in this assay, from the lowest: compounds 1, 2 and 3 (each within the scatter of the next).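

In this assay, the hydroxy group on the indole now has its first measured test: hydroxy in place of hydrogen on an aromatic carbon gives a 1.8-fold higher number from compound 1 to compound 3 (0.24 log units; within the scatter), so this addition to the 1H-indol-2-yl group cannot be told apart from no effect. Exchanging benzyloxy for 4-hydroxy-1H-indol-2-yl on the carbonyl carbon gives a 1.5-fold higher number from compound 2 to compound 3 (0.16 log units; within the scatter), so this place, on a carbonyl carbon whose other neighbour is an amide-type nitrogen, has now carried three different groups, and all three numbers lie within the scatter of one another. No measured evidence bears on why these groups read alike in this assay.

Going by these compounds, whether a methoxy group or an amine on the indole, or a carboxylic acid-bearing group in place of the benzyloxy, would move the number beyond the scatter remains open. Also open, on these data alone, is whether this place matters less than the parts shared by all three compounds, such as the benzyl group on the other amide or the length of the carbon chain, where a shorter or longer chain would be the direct test.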